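Alpha and gamma ester variants of a diaminopteridine antifolate

The source may hold more compounds than are shown below. What is called first, only, known or untested is meant among the compounds shown, and "the series" means these compounds.

Measured so far:
compound 1 `CN(Cc1cnc2nc(N)nc(N)c2n1)c1ccc(C(=O)NC(CCC(=O)O)C(=O)OC(C)(C)C)cc1` gives 0.035 uM
compound 2 `CN(Cc1cnc2nc(N)nc(N)c2n1)c1ccc(C(=O)NC(CCC(=O)OC(C)(C)C)C(=O)O)cc1` gives 0.0029 uM
compound 3 `COC(=O)CCC(NC(=O)c1ccc(N(C)Cc2cnc3nc(N)nc(N)c3n2)cc1)C(=O)OC(C)(C)C` gives 0.019 uM

All three were tested in an assay on L1210 cells for inhibition of Dihydrofolate reductase (Mus musculus); a higher number here means a weaker inhibitor, a lower number a stronger inhibitor. Compound 1 and compound 2 have the same atoms joined differently; the difference between the two cores is not broken down here. Compound 2 stands at the lowest number of the three, and its gap to compound 3 and to compound 1 lies beyond the scatter in each case.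

One change appears twice. From compound 1 to compound 3 it reads (methyl in place of hydrogen on an oxygen next to a carbonyl group), and the step was a 1.8-fold lower number from compound 1 to compound 3 (0.27 log units; within the scatter). The same change, on the core of compound 2, gives compound 4 `COC(=O)C(CCC(=O)OC(C)(C)C)NC(=O)c1ccc(N(C)Cc2cnc3nc(N)nc(N)c3n2)cc1`: methyl in place of hydrogen on an oxygen next to a carbonyl group. The two place lines read alike, so the change is the same in kind and surroundings.

Among the measured compounds shown here, because a 1.8-fold lower number from compound 1 to compound 3 (0.27 log units; within the scatter) was within the scatter, a small step is the first expectation; yet compound 4, like compound 3, carries no carboxy group, and compound 3 stands 0.019 uM. The step from compound 2 to compound 4 is therefore estimated at a 4.1-fold higher number from compound 2 to compound 4 (0.62 log units; beyond the scatter), somewhat larger than the earlier one.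

Compound 4 is estimated at 0.012 uM, expected between 0.004 uM and 0.035 uM.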

Compound 4, concentration for 50% inhibition: 0.011 uM
Compound 4: the middle estimate sits 1.1-fold (0.04 log units) above what was measured; low and high end bracket the measured number.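

On the core of compound 2 in this assay, carboxy to methoxycarbonyl gives a 3.8-fold higher number from compound 2 to compound 4 (0.58 log units; beyond the scatter). The same change does not carry a fixed step from one core to the other in this assay: the same change on two cores in this assay, a 1.8-fold lower number (0.27 log units; within the scatter) from compound 1 to compound 3 and a 3.8-fold higher number (0.58 log units; beyond the scatter) from compound 2 to compound 4, 7.0-fold (0.84 log units) apart, beyond the scatter of two such steps This shows that a step read on the core of compound 1 could not be transferred unchanged to the core of compound 2, but it rests on one pair of steps and does not show why they differ or how the change would behave on any further core.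

The compounds shown carry only methyl and tert-butyl esters beside the free carboxy group, so a longer chain such as an ethyl ester, or an amide in place of an ester, remains open on both cores. Also open, as far as these compounds go, is how the parent with two free carboxylic acids would stand against these esters.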